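This account rests on a few compounds, and the source may have more. Where it says the series, first, only, none or still open, it means among the compounds named here.

Measured compounds:
- compound 1, `COCOc1cc(/C=C/C(=O)OCC(=O)NCc2ccco2)ccc1OCc1ccccc1`, in a functional assay on LS174T cells (Homo sapiens) for cytotoxicity, read by MTT assay, with a stated time of 72 h (on this read-out higher numbers stand for weaker inhibition and lower numbers for stronger inhibition), gives > 200000 nM, a limit of the assay and not a number
- compound 2, `CCOc1ccc(COc2c(OC)cc(/C=C/C(=O)OCC(=O)Nc3ccc(Cl)cc3)cc2OC)cc1`, gives > 200000 nM, again a limit and not a number
- compound 3, `O=C(COC(=O)/C=C/c1ccc(O)c(O)c1)Nc1ccc(Cl)cc1`, gives 108000 nM

Among the compounds with values here, compound 3 is the only one of the three with a number in this assay; the other two sit at the limit of > 200000 nM in this assay, at which 2 of the 3 values shown sit, so nothing can be said about how compound 3 stands against compound 1 or compound 2 beyond that it is the one with a measurable value. Within the shared core, compound 3 carries a 4-chlorophenyl group on the amide-type nitrogen.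

Compound 4, `O=C(COC(=O)/C=C/c1ccc(O)c(O)c1)NN1CCOCC1`, has not yet been measured in this assay. It differs from compound 3 in one place: morpholin-4-yl in place of 4-chlorophenyl on an amide-type nitrogen. Within the data shown here, no measured pair shows this kind of change, so there is no direct guide to its size or direction. Given that compound 3 already gives 108000 nM, the step from compound 3 to compound 4 is expected to be small and within the scatter, or toward weaker inhibition, a 1.4-fold higher number from compound 3 to compound 4 (0.14 log units; within the scatter). Compound 4 is therefore expected to give about 150000 nM, with a range from 60000 nM to 250000 nM, and a real chance that the assay reports only a limit.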

Compound 4, half-maximal inhibitory concentration: > 200000 nM
Compound 4: no number, only a limit (the forecaster's own chance of this, stated with the estimate: 40%); at least 1.3-fold (0.12 log units) between middle value and limit.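

This is the first pair shown that differs in one place: in this assay, morpholin-4-yl in place of 4-chlorophenyl on an amide-type nitrogen gives an at least 1.8-fold higher number from compound 3 to compound 4 (0.26 log units; that floor lies within the scatter). The change therefore points toward weaker inhibition or toward no real change, since compound 4 gives only a limit of the assay, not a number, and the floor of the step lies within the scatter. The pair gives only this floor and no true size for the change, and the assay has little room to show more at this end of its range: the limit of > 200000 nM in this assay, at which 3 of the 4 values shown sit.

On these data alone, it remains open whether another group on this nitrogen, such as phenyl without the chlorine, 4-methoxyphenyl or benzyl, would give a lower number than compound 3, at 108000 nM. Also open, as far as these compounds go, is what an open-chain amine such as dimethylamino, or a longer carbon chain ending in a carboxylic acid, would do at the same place.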